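Ortho versus para substitution on a pendant phenyl ring

This account rests on a few compounds, and the source may have more. Where it says the series, first, only, none or still open, it means among the compounds named here.

Measured compounds:
compound 1 `COc1ccc(-c2cn3ccnc3c(-c3ccc4ncn(C5CCCCC5)c4c3)n2)cc1`: 93.3%
compound 2 `Fc1ccc(-c2cn3ccnc3c(-c3ccc4ncn(C5CCCCC5)c4c3)n2)cc1`: 33.4%
compound 3 `COc1ccccc1-c1cn2ccnc2c(-c2ccc3ncn(C4CCCCC4)c3c2)n1`: 17.4%

Of the compounds shown here, three sharing one core have been measured in a functional assay on CCRF-CEM cells (Homo sapiens) for inhibition, read by sulforhodamine B assay, with a stated time of 48 h, tested at 10 uM; on this read-out higher numbers stand for more inhibition at the one concentration tested (going by the name of the read-out) and lower numbers for less inhibition. Compound 1 gives 93.3%. Compound 2 differs from compound 1 by fluoro in place of methoxy on an aromatic carbon. Compound 2 gives 33.4%, so that a number 59.9 percentage points lower from compound 1 to compound 2 (beyond the scatter). Compound 3 differs from compound 1 by 2-methoxyphenyl in place of 4-methoxyphenyl on an aromatic carbon. Compound 3 gives 17.4%, a result that stands a number 75.9 percentage points lower from compound 1 to compound 3 (beyond the scatter) and also a number 16 percentage points lower from compound 2 to compound 3 (beyond the scatter). Compound 3 thus has the lowest value of the three, and its steps to both other compounds lie beyond the scatter.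

Compound 4 `Fc1ccccc1-c1cn2ccnc2c(-c2ccc3ncn(C4CCCCC4)c3c2)n1` has not been measured in this assay. It differs from compound 3 by fluoro in place of methoxy on an aromatic carbon. For the measured compounds named here, this is the same kind of change as the one from compound 1 to compound 2, but the place differs: in the earlier pair the carbon was para to a large group, here it is ortho to a large group. The earlier step was large and downward, a number 59.9 percentage points lower from compound 1 to compound 2 (beyond the scatter). Compound 3 already sits low, so the room for a further fall is limited by the floor of the read-out. Compound 4 is therefore expected to lie a little below compound 3, with an estimated step of a number 9.4 percentage points lower from compound 3 to compound 4 (within the scatter), resting on the direction seen in compound 1 and compound 2 and on the low starting value of compound 3. The estimate for compound 4 in this assay is 8%, with a range from -10% to 30%.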

Compound 4, a percentage reported as inhibition, at one concentration (the size of the read-out at that concentration, not a potency): 22.5%
The estimate for compound 4 lay 14.5 percentage points below the measured number, and the stated range covers the measured number.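

In this assay, for the compounds shown here, fluoro in place of methoxy on the 2-methoxyphenyl compound gives a number 5.1 percentage points higher from compound 3 to compound 4 (within the scatter), so the large fall seen with the same change on the 4-methoxyphenyl compound does not carry over to this second core, and the two steps differ: the same change on two cores in this assay, a number 59.9 percentage points lower (beyond the scatter) from compound 1 to compound 2 and a number 5.1 percentage points higher (within the scatter) from compound 3 to compound 4, 65 percentage points apart, beyond the scatter of two such steps The change of core itself also counts among the fluoro compounds, with a number 10.9 percentage points lower from compound 2 to compound 4 (beyond the scatter), while the widest contrast is a number 70.8 percentage points lower from compound 1 to compound 4 (beyond the scatter), which leaves compound 1 as the only one of the four compounds with a high number. What this does not show is why the outcome depends on the core, or how the change would behave on any further core, since it rests on just two matched pairs, each read at a single concentration in one cell line.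

The compounds shown leave open whether a hydroxy group or an amine in place of the methoxy of compound 1 would keep its high number, and whether a longer chain such as ethoxy would do the same. They also leave open how potent compound 1 is, since a single concentration gives the size of the inhibition there and no potency.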